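This account rests on a few compounds, and the source may have more. Where it says the series, first, only, none or still open, it means among the compounds named here.

In a functional assay on PC-3 cells (Homo sapiens) for antiproliferative activity, read by MTT assay, with a stated time of 24 h (on this read-out lower numbers stand for stronger inhibition and higher numbers for weaker inhibition), compound 1 `O=C1O/C(=C\Cn2cc(Cc3ccccc3)nn2)C(OCc2ccccc2)=C1OCc1ccccc1` gives 71300 nM. Compound 2 `CC(C)(C)c1ccc(-c2cn(C/C=C3\OC(=O)C(OCc4ccccc4)=C3OCc3ccccc3)nn2)cc1` returns only the limit of the assay, > 100000 nM, not a number. Compound 3 `Cc1ccc(-c2cn(C/C=C3\OC(=O)C(OCc4ccccc4)=C3OCc3ccccc3)nn2)cc1` likewise returns only a limit, > 100000 nM. The two measured steps away from compound 1 are therefore floors rather than sizes: an at least 1.4-fold higher number from compound 1 to compound 2 (0.14 log units; that floor lies within the scatter) and an at least 1.4-fold higher number from compound 1 to compound 3 (0.14 log units; that floor lies within the scatter). Between the two limits the step cannot be read at all: a step that the two limits leave unreadable from compound 2 to compound 3. On the numbers shown, compound 3 thus sits at the limit of > 100000 nM in this assay, at which 2 of the 3 values shown sit, and nothing separates it from compound 2, while the floor of its step from compound 1 is too small to place it apart from compound 1 with confidence.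

Compound 4 `O=C1O/C(=C\Cn2cc(C3=CCCCC3)nn2)C(OCc2ccccc2)=C1OCc1ccccc1` differs from compound 3 in one place: cyclohex-1-en-1-yl in place of 4-methylphenyl on an aromatic carbon. Within the data shown here, no measured step swaps an aromatic six-membered ring for a non-aromatic one at this position, so the bearing evidence is indirect. The step of an at least 1.4-fold higher number from compound 1 to compound 3 (0.14 log units; that floor lies within the scatter) shows that a six-membered ring attached directly to the five-membered aromatic ring with 3 nitrogen reaches the floor; compound 4 keeps such a directly attached six-membered ring, and the unreadable step that the two limits leave unreadable from compound 2 to compound 3 gives no sign that the identity of that ring moves the number. The expected step is therefore small, a number no higher from compound 3 to compound 4 (the limit leaves the size open), with a strong chance of another limit. Compound 4 is estimated at 100000 nM, expected to fall between 40000 nM and 300000 nM.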

Compound 4, half-maximal inhibitory concentration: 55600 nM
Beside the measured number, compound 4's estimate is 1.8-fold (0.25 log units) above it, and the stated range covers the measured number.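

Putting cyclohex-1-en-1-yl in place of 4-methylphenyl on this aromatic carbon yields a number in this assay rather than a limit, which no directly attached aromatic six-membered ring shown here does, giving an at least 1.7-fold lower number from compound 3 to compound 4 (0.25 log units; that floor lies within the scatter) and, against the 4-(tert-butyl)phenyl compound, an at least 1.7-fold lower number from compound 2 to compound 4 (0.25 log units; that floor lies within the scatter). Compound 4 also reads alike with the benzyl compound, with a 1.3-fold lower number from compound 1 to compound 4 (0.11 log units; within the scatter), so a six-membered ring attached directly at this position does not by itself bring the value to the limit. Only compound 2 and compound 3, which carry a substituted phenyl ring here, stand at a limit: the limit of > 100000 nM in this assay, at which 2 of the 4 values shown sit.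

All three new steps stay within the scatter or have floors within it, the step between compound 2 and compound 3 cannot be read, and the series therefore does not establish that losing the aromatic ring moves the number. Also open, on these data alone, is whether cyclohexyl, an amine or a carboxylic acid on the ring, or a longer chain at this position would shift the value beyond the scatter.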